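A few compounds are considered here, and "the series" means these few. Any claim that something is new, unique, unknown or untested is made for them only; others in the source may bear on it.

Measured so far in an ADME assay on SK-OV-3 cells (Homo sapiens) for cytotoxicity, read by sulforhodamine B assay, with a stated time of 48 h, tested at 10 uM; a higher number here means more inhibition at the concentration tested (going by the name of the read-out), a lower number less inhibition:

- Compound 1, `COc1nc2ccc(Br)cc2cc1C(c1ccccc1)n1cc(CCCO)nn1`: 13.8%
- Compound 2, `COc1nc2ccc(Br)cc2cc1C(c1ccccc1)n1cc(-c2ccccc2C(F)(F)F)nn1`: 9.55%

Both measured compounds share one core and differ only in the group carried on the five-membered aromatic ring with three nitrogens. Compound 2 gives the lower of the two numbers, but the step of a number 4.3 percentage points lower from compound 1 to compound 2 (within the scatter) is within the scatter, so the two values cannot be told apart; both show little inhibition at the tested concentration.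

Going by the values given here, compound 3, `COc1nc2ccc(Br)cc2cc1C(c1ccccc1)n1cc(-c2cccc(F)c2)nn1`, keeps the core of compound 2 and alters only that same group: 3-fluorophenyl in place of 2-(trifluoromethyl)phenyl on an aromatic carbon. Among the compounds with values here, no measured step bears directly on this exchange of one aromatic ring for another; the only step at hand, a number 4.3 percentage points lower from compound 1 to compound 2 (within the scatter), replaced a short chain with an aromatic ring and stayed within the scatter. With both measured numbers low and close together, no step beyond the scatter is expected in this assay from compound 2 to compound 3, and the expected step of a number 1.5 percentage points higher from compound 2 to compound 3 (within the scatter) reflects this. Compound 3 is therefore estimated at 11%, within 0% to 25%.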

Compound 3, a percentage reported as inhibition, at one concentration (the size of the read-out at that concentration, not a potency): 12.7%
Compound 3: middle estimate off by 1.7 percentage points, on the low side; measured number inside the range.
By their numbers in this assay, from the lowest: compounds 2, 3 and 1 (each within the scatter of the next).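

Exchanging 2-(trifluoromethyl)phenyl for 3-fluorophenyl on this aromatic carbon of the five-membered ring takes the group from 10 heavy atoms to 7 while keeping one six-membered aromatic ring of carbon only, and in this assay the result is a number 3.2 percentage points higher from compound 2 to compound 3 (within the scatter), so this change within the aromatic groups cannot be distinguished from no effect. The comparison with the flexible chain gives a number 1.1 percentage points lower from compound 1 to compound 3 (within the scatter), which means that 3-hydroxypropyl and 3-fluorophenyl also cannot be told apart, and all three groups at this position leave inhibition small at the tested concentration. No independent measurement is available to explain why these different groups give such similar results.

From the compounds shown here alone, what remains open is whether an amine, a carboxylic acid or a longer chain on this carbon would give a number beyond the scatter of these three compounds. The compounds shown also leave open whether an unsubstituted phenyl ring or a 4-methoxyphenyl group at this position would behave in the same way.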